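The source may report more compounds than this note shows. Statements on the series, on what has been measured and on what is new or still open speak of the compounds shown alone.

Compound 3 `Nc1ccccc1NC(=O)/C=C/c1ccc(CSc2ccc(F)cc2)cc1` gives 7.09% in a functional assay on HeLa cells (Homo sapiens) for inhibition, read by CCK-8 assay, with a stated time of 72 h, tested at 2 uM (a higher number here means more inhibition of growth at the concentration tested, a lower number less inhibition of growth), the lowest of the three numbers measured; compound 2 `COc1ccc(SCc2ccc(/C=C/C(=O)Nc3ccccc3N)cc2)cc1OC` gives 10.1%, within the scatter of it, while compound 1 `Cc1ccc(SCc2ccc(/C=C/C(=O)Nc3ccccc3N)cc2)cc1` gives 25.5%, and the gap a number 18.4 percentage points lower from compound 1 to compound 3 (beyond the scatter) lies beyond the scatter. Compound 4 `Nc1ccccc1NC(=O)/C=C/c1ccc(CSc2ccc(Cl)cc2)cc1` differs from compound 3 by chloro in place of fluoro on an aromatic carbon. Among the measured compounds shown here, no measured step swaps one halogen for another; the only step touching this carbon is a number 18.4 percentage points lower from compound 1 to compound 3 (beyond the scatter), and a number 15.4 percentage points lower from compound 1 to compound 2 (beyond the scatter) changes the whole ring. Neither speaks for a move as large as either of those, so the expected change a number 3.9 percentage points higher from compound 3 to compound 4 (within the scatter) is small and likely within the scatter. For compound 4 the estimate in this assay is 11%, with a range from 0% to 26%.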

Compound 4, percent growth inhibition at one concentration: 1.94%
The estimate for compound 4 lay 9.1 percentage points above the measured number; the measured number falls inside the stated range.
By their numbers in this assay, from the lowest: compounds 4, 3 and 2 (each within the scatter of the next); then compound 1.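

In this assay, among the compounds shown here, the first exchange of one halogen for another at this aromatic carbon gives a number 5.2 percentage points lower from compound 3 to compound 4 (within the scatter), so chloro and fluoro cannot be told apart here. With a number 8.2 percentage points lower from compound 2 to compound 4 (within the scatter) and a number 23.6 percentage points lower from compound 1 to compound 4 (beyond the scatter), both halogen compounds sit with the 3,4-dimethoxyphenyl compound, and only the 4-methylphenyl compound stands apart. Nothing available explains this pattern. From the compounds shown here alone, whether methyl is unusual at this carbon remains open, since an ethyl group, a trifluoromethyl group or an amine there could show whether compound 1 stands alone.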